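The compounds below may be only part of what the source reports. "The series", "measured", "known", "first", "only" and "open" are said of these compounds alone.

Working notes on the series. All three measured members carry the shared core with the anilide-bearing side chain, seen in compound 1 `O=C(O)CN1C(=O)/C(=C/c2ccc(OCC(=O)Nc3cccc(Cl)c3)cc2)SC1=S` and compound 3 `O=C(COc1ccc(/C=C2\NC(=O)N(Cc3ccccc3)C2=O)cc1)Nc1cccc(Cl)c1` and, with a methoxy group on the ring nitrogen's chain carbon, in compound 2 `COCN1C(=O)S/C(=C\c2ccc(OCC(=O)Nc3cccc(Cl)c3)cc2)C1=O`. In a functional assay on RAW264.7 cells (Mus musculus) for inhibition, read by Griess assay, with stated times of 2 h and 18 h (a lower number here means a stronger inhibitor, a higher number a weaker inhibitor), compound 1 gives 68900 nM and compound 3 gives 75400 nM. For compound 2 this assay reports only a limit, > 80000 nM, not a number; the limit is the one described in the limit of > 80000 nM in this assay, at which 1 of the 3 values shown sits. Compound 2 therefore stands at the weak end of what the three values show, without a measured position of its own.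

The next member, compound 4 `CC(CN(C)C)CN1C(=O)S/C(=C\c2ccc(OCC(=O)Nc3cccc(Cl)c3)cc2)C1=O`, differs from compound 2 by 1-((dimethylamino)methyl)ethyl in place of methoxy on a saturated chain carbon bound to an amide-type nitrogen in a ring. Among the measured compounds shown here, no pair of measured compounds shares this change, so nothing in the data sets its direction or size; the two numbered values and the one limit all sit in the same weak region. The step from compound 2 to compound 4 is therefore expected to be an at least 1.0-fold lower number from compound 2 to compound 4 (0.02 log units; that floor lies within the scatter), in either direction within scatter or none. Compound 4 is expected to give about 75000 nM in this assay, within 25000 nM to 200000 nM, with a real chance that only a limit is returned.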

Compound 4, half-maximal inhibitory concentration: 53200 nM
Beside the measured number, compound 4's estimate is 1.4-fold (0.15 log units) above it, within the range that was stated.
By their numbers in this assay, from the lowest: compounds 4, 1 and 3 (each within the scatter of the next). At a limit, above all of these: compound 2.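

Replacing methoxy with 1-((dimethylamino)methyl)ethyl on a saturated chain carbon bound to an amide-type nitrogen in a ring gives, in this assay, an at least 1.5-fold lower number from compound 2 to compound 4 (0.17 log units; that floor lies within the scatter). Among the compounds shown here, this is the first step that can be read at all, and it shows that this position accepts the larger basic-named chain while the read-out still returns a number for compound 4, though the floor of the step establishes no real gain. The true size of the step stays unknown, since its starting point is only a limit for compound 2: the limit of > 80000 nM in this assay, at which 1 of the 4 values shown sits.

The compounds shown do not separate the contribution of the dimethylamino group from that of the carbon chain carrying it; a 2-methylpropyl chain with no amine, or a morpholine in place of the dimethylamino group on the same chain, would address that on the same core. Going by these compounds, whether any group at this position can move the number clear of the scatter also remains open.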